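The source may report more compounds than this note shows. Statements on the series, on what has been measured and on what is new or still open speak of the compounds shown alone.

Compound 3, `C=CC1=C(C(=O)NC2CCCCC2)C(c2ccc(F)cc2)OC1`, stands at the higher of the two numbers given in a functional assay on QGY7701 cells (Homo sapiens) for cytotoxicity, read by MTT assay, with a stated time of 24 h (on this read-out lower numbers stand for stronger inhibition and higher numbers for weaker inhibition), where compound 3 gives 40500 nM. Its nearest neighbour is compound 2, `C=CC1=C(C(=O)NCc2ccc(Cl)cc2)C(c2ccc(F)cc2)OC1`, which in this assay gives 36900 nM; the step of a 1.1-fold higher number from compound 2 to compound 3 (0.04 log units; within the scatter) shows no difference beyond the scatter. Among the compounds with values here, compound 1, `C=CC1=C(C(=O)NCc2ccccc2)C(c2ccc(OC)cc2)OC1`, gives in this assay only a limit, > 100000 nM; it carries the same benzyl amide as compound 4 but a methoxy-substituted phenyl on the core, so no single step joins it to compound 4.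

Compound 4, `C=CC1=C(C(=O)NCc2ccccc2)C(c2ccc(F)cc2)OC1`, differs from compound 3 by benzyl in place of cyclohexyl on an amide-type nitrogen. Within the data shown here, the one measured step that bears on the amide nitrogen, a 1.1-fold higher number from compound 2 to compound 3 (0.04 log units; within the scatter), lay within the scatter, so a cyclohexyl and a 4-chlorobenzyl behaved alike there; benzyl is expected to sit in the same range or somewhat weaker, with a limit a real possibility. For compound 4 the step of a 1.5-fold higher number from compound 3 to compound 4 (0.17 log units; within the scatter) is therefore expected, and compound 4 is estimated at 60000 nM, between 25000 nM and 150000 nM.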

Compound 4, half-maximal inhibitory concentration: 67600 nM
For compound 4 the middle estimate is 1.1-fold (0.05 log units) below the measured one, within the range that was stated.
By their numbers in this assay, from the lowest: compounds 2, 3 and 4 (each within the scatter of the next). At a limit, above all of these: compound 1.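

Read in this assay, the amide-type nitrogen now shows a third group without any step beyond the scatter: benzyl in place of cyclohexyl gives a 1.7-fold higher number from compound 3 to compound 4 (0.22 log units; within the scatter) and hydrogen in place of chloro on an aromatic carbon gives a 1.8-fold higher number from compound 2 to compound 4 (0.26 log units; within the scatter) as its step. A non-aromatic ring, an aromatic ring and a chlorinated aromatic ring on this nitrogen thus cannot be told apart among compound 2, compound 3 and compound 4. Fluoro in place of methoxy on an aromatic carbon reads as an at least 1.4-fold lower number from compound 1 to compound 4 (0.17 log units; that floor lies within the scatter) and gives a floor rather than a size, since compound 1 is held only at a limit: the limit of > 100000 nM in this assay, at which 1 of the 4 values shown sits.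

The compounds shown leave open whether an amine or a carboxylic acid on the benzyl group, or a longer chain on the amide-type nitrogen, would move the number beyond the scatter. They also leave open how fluoro and methoxy compare when the nitrogen carries cyclohexyl or 4-chlorobenzyl.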